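A few compounds are considered here, and "the series" means these few. Any claim that something is new, unique, unknown or untested is made for them only; others in the source may bear on it.

Measured so far in a functional assay on HL-60 cells (Homo sapiens) for cytotoxicity, read by MTT assay, with a stated time of 72 h; on this read-out higher numbers stand for weaker inhibition and lower numbers for stronger inhibition:
compound 1, `COCOc1cc(/C=C/C(=O)OCC(=O)Nc2ccc(Cl)cc2)ccc1OCc1ccccc1`: > 200000 nM, which is a limit of the assay and not a number.
compound 2, `COCOc1cc(/C=C/C(=O)OCC(=O)NN2CCOCC2)ccc1OCc1ccccc1`: 50400 nM.

Compound 2 holds the only number shown in this assay; the other value is a limit. Going by the values given here, the one measured step, an at least 3.9-fold lower number from compound 1 to compound 2 (0.59 log units; beyond the scatter), is bounded on the compound 1 side by the limit of > 200000 nM in this assay, at which 1 of the 2 values shown sits, so only its minimum size is known.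

Compound 3 is `COCOc1cc(/C=C/C(=O)OCC(=O)Nc2nccs2)ccc1OCc1ccccc1`. Relative to compound 2 the change is 1,3-thiazol-2-yl in place of morpholin-4-yl on an amide-type nitrogen. Among the compounds with values here, no measured step covers this exchange directly: the one step known replaces an aryl group on the amide-type nitrogen by morpholin-4-yl, whereas here morpholin-4-yl gives way to an aromatic five-membered ring, and compound 1 with its aryl substituent sits at the limit. The expectation is therefore a weaker result than compound 2, an estimated step of a 2.2-fold higher number from compound 2 to compound 3 (0.34 log units; beyond the scatter), though with a wide band, and a limit result in this assay cannot be excluded. For compound 3 the estimate in this assay is 110000 nM, within 30000 nM to 250000 nM.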

Compound 3, half-maximal inhibitory concentration: > 200000 nM
Compound 3: a limit, no number (the forecaster's own chance of this, stated with the estimate: 35%); at least 1.8-fold (0.25 log units) between middle value and limit.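

In this assay, 1,3-thiazol-2-yl in place of morpholin-4-yl on the amide-type nitrogen gives an at least 3.9-fold higher number from compound 2 to compound 3 (0.59 log units; beyond the scatter), so a five-membered aromatic ring at this position does not keep the number that morpholin-4-yl gives, and with the earlier step the position now shows a change in both directions around that one group. Compound 3 gives > 200000 nM, which is a limit of the assay and not a number. Among the compounds shown, both aromatic rings on this nitrogen, 4-chlorophenyl in compound 1 and 1,3-thiazol-2-yl in compound 3, end at one limit, so the step between them cannot be read: the limit of > 200000 nM in this assay, at which 2 of the 3 values shown sit.

Open, as far as these compounds go, is whether a measurable value in this assay belongs to morpholin-4-yl alone or also to other non-aromatic groups on this nitrogen, such as piperidin-1-yl or a dimethylamino group. Going by these compounds alone, also open is whether any change at this position gives a number lower than the one of compound 2, 50400 nM, for instance a basic piperazin-1-yl ring or a carboxylic acid on a longer chain.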